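The source may hold more compounds than are shown below. What is called first, only, known or untested is meant among the compounds shown, and "the series" means these compounds.

Compound 1 `CC1=C(C(C)C(=O)NCCN2CCCC2)c2cc(F)ccc2/C1=C\c1ccc([S+](C)[O-])cc1` sets the reference level: in a functional assay on MDA-MB-231 cells (Homo sapiens) for inhibition, read by CellTiter-Glo, with a stated time of 96 h (a lower number here means that less compound is tolerated, a higher number that more compound is tolerated), compound 1 gives 39300 nM. Compound 2 `CC1=C(C(C)C(=O)NCCN2CCCCC2)c2cc(F)ccc2/C1=C\c1ccc([S+](C)[O-])cc1` carries piperidin-1-yl in place of pyrrolidin-1-yl on a saturated chain carbon, two bonds along the chain from an amide-type nitrogen, and in this assay compound 2 gives 39300 nM. That step, no change at the digits printed from compound 1 to compound 2 (within the scatter), leaves the series flat at the digits shown, so compound 2 stands level with compound 1.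

Compound 3 `CC1=C(C(C)C(=O)NCCN2CCNCC2)c2cc(F)ccc2/C1=C\c1ccc([S+](C)[O-])cc1` is the next member. Its change from compound 2 is piperazin-1-yl in place of piperidin-1-yl on a saturated chain carbon, two bonds along the chain from an amide-type nitrogen. Within the data shown here, the only step that bears on it is the ring exchange at the same place, no change at the digits printed from compound 1 to compound 2 (within the scatter), which stayed within the scatter. On that basis no step beyond the scatter is expected, and the estimated step is no change at the digits printed from compound 2 to compound 3 (within the scatter). For compound 3 in this assay the expected value is 39300 nM, with a range from 15000 nM to 90000 nM.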

Compound 3, half-maximal cytotoxic concentration: > 50000 nM
Compound 3 was reported as a limit (the forecaster's own chance of this, stated with the estimate: 20%); middle value at least 1.2-fold (0.10 log units) from the limit.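

In this assay compound 3 is reported only as a limit, > 50000 nM. The steps read an at least 1.2-fold higher number from compound 2 to compound 3 (0.10 log units; that floor lies within the scatter) and an at least 1.2-fold higher number from compound 1 to compound 3 (0.10 log units; that floor lies within the scatter), so piperazin-1-yl in place of piperidin-1-yl or pyrrolidin-1-yl on this saturated chain carbon gives only a floor inside the scatter, and the true size of either step cannot be read. Unlike the exchange of pyrrolidin-1-yl for piperidin-1-yl, which left the digits unchanged, this exchange takes the reading to the limit of the assay: the limit of > 50000 nM in this assay, at which 1 of the 3 values shown sits.

The compounds shown leave open how far compound 3 lies past that limit, and so whether the change has any real size. They also leave open whether the ring nitrogen that enters or its hydrogen counts, which morpholin-4-yl or 4-methylpiperazin-1-yl at the same place would help separate.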